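Pyridinyl to imidazolylmethyl on the shared naphthalene-type core

The source may report more compounds than this note shows. Statements on the series, on what has been measured and on what is new or still open speak of the compounds shown alone.

Measured so far:
compound 1 `Fc1ccc(-c2ccc3c(-c4cccnc4)cccc3c2)cc1`: 2%
compound 2 `Oc1ccc2cc(-c3ccc(F)cc3)ccc2c1-c1cccnc1`: 0%

In an assay for inhibition of steroid 17-alpha-hydroxylase/17,20 lyase (Homo sapiens), tested at 0.2 uM (a higher number here means a stronger effect of the compound at the concentration tested, a lower number a weaker effect), compound 1 gives 2% and stands highest of the two numbers, though its nearest neighbour compound 2 lies within the scatter: a number 2 percentage points lower from compound 1 to compound 2 (within the scatter). Compound 3 `Fc1ccc(-c2ccc3c(Cn4ccnc4)cccc3c2)cc1` differs from compound 1 by (1H-imidazol-1-yl)methyl in place of pyridin-3-yl on an aromatic carbon. Going by the values given here, no measured step touches this position or this group; the one step known, hydroxy for hydrogen, is within the scatter and does not bear on it. Compound 3 is therefore expected near compound 1, with a step of a number 4 percentage points higher from compound 1 to compound 3 (within the scatter) in this assay. The estimate for compound 3 is 6%, ranging from 0% to 30%.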

Compound 3, a percentage reported as inhibition, at one concentration (the size of the read-out at that concentration, not a potency): 2%
Beside the measured number, compound 3's estimate is 4 percentage points above it; the measured number falls inside the stated range.
By their numbers in this assay, from the lowest: compounds 2, 1 and 3 (each within the scatter of the next).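

The step at this aromatic carbon reads no change at the digits printed from compound 1 to compound 3 (within the scatter) in this assay. Going by these compounds alone, exchanging pyridin-3-yl for (1H-imidazol-1-yl)methyl, a five-membered aromatic ring with 2 hetero atoms in place of a six-membered one with 1, therefore leaves the read-out at this single concentration without a visible step, and this is the first reading of this position. Nothing available explains this result.

On these data alone, whether a longer chain carrying the imidazole, an amine or a carboxylic acid at this aromatic carbon would separate from compound 1 stays open. A single-concentration read-out also leaves any potency difference between compound 1 and compound 3 unresolved.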